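The source may report more compounds than this note shows. Statements on the series, on what has been measured and on what is new or still open speak of the compounds shown alone.

In a functional assay on OCI-Ly3 cells (Homo sapiens) for antiproliferative activity (a lower number here means that less compound is needed, a higher number that more compound is needed for the effect), compound 1 `Cc1c(NC(=O)Nc2cnc(-n3nccn3)c(Cl)c2)cnc2ccccc12` gives 7170 nM while compound 3 `COC(C)c1c(NC(=O)Nc2cnc(-n3nccn3)c(Cl)c2)cnc2ccccc12` gives 620 nM on the same scale, a 12-fold lower number from compound 1 to compound 3 (1.06 log units; beyond the scatter) when 1-methoxyethyl stands in place of methyl. Compound 2 `O=C(Nc1cnc(-n2nccn2)c(Cl)c1)Nc1cnc2ccc(F)cc2c1C1CC1` gives 720 nM in this measure, within the scatter of compound 3. Going by the values given here, compound 4 `COC(C)c1c(NC(=O)Nc2cnc(-n3nccn3)c(Cl)c2)cnc2ccc(F)cc12` has fluoro in place of hydrogen on an aromatic carbon as its only difference from compound 3. Among the compounds with values here, no measured step isolates this change. Within the data shown here, the one measured step concerns another group, and compound 2 carries a fluoro but also differs from compound 3 in a second place. No step beyond the scatter is therefore expected in this assay, and no direction can be favoured. Compound 4 is expected near 550 nM with an estimated range from 200 nM to 1500 nM for its measurement.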

Compound 4, half-maximal effective concentration: 270 nM
Compound 4: the middle estimate sits 2.0-fold (0.31 log units) above what was measured; measured number inside the range.
By their numbers in this assay, from the lowest: compound 4; then compounds 3 and 2 (each within the scatter of the next); then compound 1.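

In this assay, going by these compounds alone, the fluoro in place of hydrogen on the aromatic carbon gives a 2.3-fold lower number from compound 3 to compound 4 (0.36 log units; beyond the scatter) and so has a modest effect beyond the scatter, which no earlier step could show. With the fluoro present on both sides, 1-methoxyethyl in place of cyclopropyl gives a 2.7-fold lower number from compound 2 to compound 4 (0.43 log units; beyond the scatter) as a second modest step. Nothing available explains either step. From the compounds shown here alone, whether a chloro, a methoxy or an amine on this same carbon would lower the number further stays open. So does whether the fluoro step holds when methyl or cyclopropyl replaces 1-methoxyethyl.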